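Removing the ester-bearing chain from compound 3

The compounds below may be only part of what the source reports. "The series", "measured", "known", "first", "only" and "open" are said of these compounds alone.

In a functional assay on the whole organism (strain Sprague-Dawley) for inhibition, with Rattus norvegicus as the target, with a stated time of 0.5 h, at a dose of 5 mg/kg by the oral route (on this read-out lower numbers stand for less inhibition and higher numbers for more inhibition at the one dose given (going by the name of the read-out)), compound 1 `CCCSc1nc(N[C@@H]2C[C@H]2c2ccc(F)c(F)c2)c2nnn([C@@H]3C[C@H](OC(=O)CC)[C@@H](O)[C@H]3O)c2n1` gives 44.5%. Compound 2 `CCCSc1nc(N[C@@H]2C[C@H]2c2ccc(F)c(F)c2)c2nnn([C@@H]3C[C@H](OCCOC(=O)CCC)[C@@H](O)[C@H]3O)c2n1` is reported in this assay as "not active" (no number reported), and compound 3 `CCCSc1nc(N[C@@H]2C[C@H]2c2ccc(F)c(F)c2)c2nnn([C@@H]3C[C@H](OCCOC(=O)c4cccnc4)[C@@H](O)[C@H]3O)c2n1` is likewise reported as "not active" (no number reported). Compound 3 therefore stands without a number of its own, alongside compound 2, while compound 1 is the only one of the three with a measured figure.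

Compound 4 `CCCSc1nc(N[C@@H]2C[C@H]2c2ccc(F)c(F)c2)c2nnn([C@@H]3C[C@H](O)[C@@H](O)[C@H]3O)c2n1` differs from compound 3 in one place: hydrogen in place of 2-(((pyridin-3-yl)carbonyl)oxy)ethyl on an oxygen on a saturated carbon. The change takes compound 3 back to the free hydroxy group on the saturated ring carbon, leaving the shared core of compound 3 otherwise untouched.

Among the measured compounds shown here, no measured step links the two, so the expectation rests on the fact that compound 1, which carries a smaller group on the same oxygen, gives 44.5%, whereas compound 3 gives "not active" (no number reported). The account expects the step from compound 3 to compound 4 in this assay to be upward and beyond the scatter. For compound 4 in this assay the estimate is 60%, expected to fall between 30% and 85%.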

Compound 4, a percentage reported as inhibition, in the whole organism at one dose (the size of the read-out at that dose, not a potency): 45.7%
Estimate against measurement, compound 4: 14.3 percentage points above; low and high end bracket the measured number.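

In this assay, the propanoyl ester on this oxygen and the free hydroxy group read alike, with a number 1.2 percentage points higher from compound 1 to compound 4 (within the scatter) for that change. Among the compounds shown here, the loss of activity therefore goes with the longer groups on this oxygen: with hydrogen there, compound 4 gives 45.7% as a measured figure, while compound 3, carrying 2-(((pyridin-3-yl)carbonyl)oxy)ethyl on the same oxygen, is reported as "not active" (no number reported) and the step between them cannot be read as a number, nor can the one from compound 2 to compound 4. Nothing measured here gives a reason for these readings.

The compounds shown leave open whether the ethyl chain or the ester on it goes with the loss. A 2-hydroxyethyl group or a plain methyl ether on this oxygen would separate the two.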